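Hydroxylation of the pivalamide terminus in a tetralin sulfone series

The compounds below may be only part of what the source reports. "The series", "measured", "known", "first", "only" and "open" are said of these compounds alone.

Measured so far:
- compound 1 `CNS(=O)(=O)NC[C@@H]1CCCc2cc(S(=O)(=O)c3cccc(F)c3)ccc21`, 1 nM
- compound 2 `CC(C)(C)C(=O)NC[C@@H]1CCCc2cc(S(=O)(=O)c3cccc(F)c3)ccc21`, 3.98 nM

In an assay on isolated protein for displacement of a labelled ligand from 5-hydroxytryptamine receptor 6 (Homo sapiens) (on this read-out lower numbers stand for stronger inhibition and higher numbers for weaker inhibition), compound 1 gives 1 nM and compound 2 gives 3.98 nM. Among the compounds with values here, the one measured step, a 4.0-fold higher number from compound 1 to compound 2 (0.60 log units; beyond the scatter), exchanges the group on the amine nitrogen. Compound 2 thus holds the higher of the two numbers, separated from compound 1 by a step beyond the scatter.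

Compound 3 `CC(C)(O)C(=O)NC[C@@H]1CCCc2cc(S(=O)(=O)c3cccc(F)c3)ccc21` keeps the (tert-butyl)carbonyl frame of compound 2 and alters it as hydroxy in place of methyl on a saturated chain carbon bound to a carbonyl carbon and two saturated chain carbons. Within the data shown here, no measured step touches this position; the step from compound 1 to compound 2 changed the whole capping group rather than one atom within it, so it offers no direct guide. A change of one heavy atom on the terminus is expected to move this assay by little, in either direction, giving an expected step of a 1.3-fold higher number from compound 2 to compound 3 (0.10 log units; within the scatter). Compound 3 is therefore estimated at 5 nM, within 1.5 nM to 16 nM.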

Compound 3, inhibition constant: 2 nM
For compound 3 the middle estimate is 2.5-fold (0.40 log units) above the measured one, within the range that was stated.
By their numbers in this assay, from the lowest: compounds 1, 3 and 2 (each within the scatter of the next, the first and the last beyond it).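

In this assay, hydroxy in place of methyl on the saturated chain carbon bound to a carbonyl carbon and two saturated chain carbons gives a 2.0-fold lower number from compound 2 to compound 3 (0.30 log units; within the scatter) and so produces no shift that can be told from repeat measurements. This single-atom change also alters the comparison with the methylsulfamoyl group: a 4.0-fold higher number from compound 1 to compound 2 (0.60 log units; beyond the scatter) stands beyond the scatter, whereas a 2.0-fold higher number from compound 1 to compound 3 (0.30 log units; within the scatter) stands within it. No evidence on the origin of this result is available.

On these data alone, whether a methoxy group, an amine or a carboxylic acid at this carbon would stay equally close to compound 2 remains open. Also open, as far as these compounds go, is whether a longer chain carrying the hydroxy would keep the number in this range.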